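The source may hold more compounds than are shown below. What is called first, only, known or untested is meant among the compounds shown, and "the series" means these compounds.

Measured in a functional assay on HeLa cells (Homo sapiens) for antiproliferative activity, read by MTT assay, with a stated time of 48 h; a lower number here means a stronger inhibitor, a higher number a weaker inhibitor:
- Compound 1 `COc1ccc(N(C)c2ccnc(Cl)n2)cc1OCCBr`: 3310 nM
- Compound 2 `COc1ccc(N(C)c2ccnc(Cl)n2)cc1OCCCCBr`: 307 nM

Compound 2 holds the lower of these two numbers. Compound 3 `COc1ccc(N(C)c2ccnc(Cl)n2)cc1OCC[Se]C#N` differs from it as follows: a group of 3 heavy atoms (1 carbon, 1 nitrogen, 1 selenium; no ring) in place of a group of 3 heavy atoms (2 carbon, 1 bromine; no ring), on a saturated chain carbon, two bonds along the chain from an oxygen on an aromatic ring. Among the measured compounds shown here, the only measured step bearing on this is an 11-fold lower number from compound 1 to compound 2 (1.03 log units; beyond the scatter), a large one, in which 2-bromoethyl entered in place of bromo. For the measured compounds named here, compound 3 loses that 2-bromoethyl, but no measured compound carries its new group. A moderate move toward a higher number in this assay is therefore expected, smaller than that step. The expected step is a 1.6-fold higher number from compound 2 to compound 3 (0.21 log units; within the scatter). For compound 3 the estimated value is 500 nM, with an expected range from 80 nM to 3000 nM.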

Compound 3, half-maximal inhibitory concentration: 436 nM
Estimate against measurement, compound 3: 1.1-fold (0.06 log units) above, and the stated range covers the measured number.
By their numbers in this assay, from the lowest: compounds 2 and 3 (each within the scatter of the next); then compound 1.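

In this assay the 2-bromoethyl is not required on this saturated chain carbon: with a 1.4-fold higher number from compound 2 to compound 3 (0.15 log units; within the scatter) the new group of carbon, nitrogen and selenium stays level with it, inside the usual scatter. Set against plain bromo, the same group gives a 7.6-fold lower number from compound 1 to compound 3 (0.88 log units; beyond the scatter) and so the gain seen earlier does not belong to 2-bromoethyl alone. No measurement here accounts for why these two different groups perform alike.
Still open, as far as these compounds go, is whether a longer chain ending in the same selenium group would do better, and whether an amine or a carboxylic acid could stand at this place.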